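Aryl swap on the cinnamoyl hydrazide series: compound 3

A few compounds are considered here, and "the series" means these few. Any claim that something is new, unique, unknown or untested is made for them only; others in the source may bear on it.

Measured so far:
compound 1 `O=C(/C=C/c1cccc(Br)c1)NNC(=O)c1ccc2c(c1)OCCO2` — 3330 nM
compound 2 `O=C(/C=C/c1ccc(F)cc1)NNC(=O)c1ccc2c(c1)OCCO2` — 990 nM

Among the measured compounds shown here, in a functional assay on cells (Cancer cell lines, Homo sapiens) for inhibition, read by MTT assay, with a stated time of 48 h (a higher number here means a weaker inhibitor, a lower number a stronger inhibitor), compound 2 gives 990 nM and stands lowest of the two numbers; its only neighbour is compound 1, with a 3.4-fold lower number from compound 1 to compound 2 (0.53 log units; beyond the scatter). Compound 3 `O=C(/C=C/c1ccccc1[N+](=O)[O-])NNC(=O)c1ccc2c(c1)OCCO2` keeps the shared core and differs from compound 2 only at the aryl end: 2-nitrophenyl in place of 4-fluorophenyl on a double-bonded chain carbon bound to a double-bonded chain carbon. For the measured compounds named here, the one measured step bears on it only loosely, showing that a change of aryl substituent on this chain carbon shifts the number modestly; no measured step covers 2-nitrophenyl itself. The expectation is a step of a 2.0-fold higher number from compound 2 to compound 3 (0.31 log units; beyond the scatter), estimated at 2000 nM for compound 3, range 700 nM to 6000 nM.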

Compound 3, half-maximal inhibitory concentration: 890 nM
Estimate against measurement, compound 3: 2.2-fold (0.35 log units) above; measured number inside the range.
By their numbers in this assay, from the lowest: compounds 3 and 2 (each within the scatter of the next); then compound 1.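

In this assay, 2-nitrophenyl in place of 4-fluorophenyl on this chain carbon gives a 1.1-fold lower number from compound 2 to compound 3 (0.05 log units; within the scatter) and so shows that two aryl groups with different substituents can read alike at this position. 2-nitrophenyl in place of 3-bromophenyl gives a 3.7-fold lower number from compound 1 to compound 3 (0.57 log units; beyond the scatter) and leaves compound 1 apart from both other compounds. Nothing available explains these numbers. Still open, from the compounds shown here alone, is how an aryl group carrying an amine or a carboxylic acid would read at this chain carbon. Also open, going by these compounds, is whether the 2-nitrophenyl result depends on the nitro group or on where it sits.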